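A furan-2-yl swap on a carbonyl carbon

The compounds below may be only part of what the source reports. "The series", "measured", "known", "first", "only" and "open" are said of these compounds alone.

Among the compounds with values here, in an ADME assay on HepG2 2.2.15 cells (Homo sapiens) for cytotoxicity, read by MTT assay (on this read-out higher numbers stand for lower toxicity in this test and lower numbers for higher toxicity in this test), compound 1 `C=C1CC[C@@H]2[C@](C)(COC(=O)/C=C/c3ccccc3)[C@H](O)CC[C@@]2(C)[C@@H]1/C=C/C1=CCOC1=O` gives 183000 nM and compound 2 `C=C1CC[C@@H]2[C@](C)(COC(=O)/C=C/c3ccccc3)[C@H](O)CC[C@@]2(C)[C@@H]1C/C=C1\C=COC1=O` gives 271000 nM, so compound 2 sits level with the only other measured number. Compound 3 `C=C1CC[C@@H]2[C@](C)(COC(=O)c3ccco3)[C@H](O)CC[C@@]2(C)[C@@H]1C/C=C1\C=COC1=O` differs from compound 2 by furan-2-yl in place of 2-phenylethenyl on a carbonyl carbon. Within the data shown here, the one measured step, a 1.5-fold higher number from compound 1 to compound 2 (0.17 log units; within the scatter), lies elsewhere in the molecule, and no measured pair shows this exchange. The expected step is therefore modest, a 1.2-fold lower number from compound 2 to compound 3 (0.07 log units; within the scatter), with nothing foreseen beyond the scatter. For compound 3 the estimated value is 230000 nM, with an expected range of 110000 nM to 480000 nM.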

Compound 3, half-maximal cytotoxic concentration: > 2150000 nM
Compound 3: only a limit was reported (the forecaster's own chance of this, stated with the estimate: 15%); middle value at least 9.3-fold (0.97 log units) from the limit.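

A change on a carbonyl carbon now moves this read-out: in this assay, furan-2-yl in place of 2-phenylethenyl gives an at least 7.9-fold higher number from compound 2 to compound 3 (0.89 log units; beyond the scatter). Within the data shown here, the only earlier step lay elsewhere in the molecule and stayed within the scatter, so this is the first sign that this position matters, with the higher number meaning lower toxicity in this test. The figure for compound 3 is a limit, not a number: the limit of > 2150000 nM in this assay, at which 1 of the 3 values shown sits.

On these data alone, the true size of the step therefore stays open. So does which part of the exchange counts, something a phenyl group or a propyl chain on the same carbonyl carbon could help separate.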